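The compounds below may be only part of what the source reports. "The series", "measured", "known", "first", "only" and "open" are said of these compounds alone.

In an assay (Ovis aries) for binding affinity to melatonin receptor type 1A (Homo sapiens) (a lower number here means a stronger inhibitor, a higher number a weaker inhibitor), compound 2 `COc1ccc2cccc(CONC(C)=O)c2c1` gives 7.94 nM. Among the measured compounds shown here, the only other measured compound, compound 1 `CNC(=O)CCc1cccc2ccc(OC)cc12`, gives 12.6 nM in this assay, and the change a 1.6-fold lower number from compound 1 to compound 2 (0.20 log units; within the scatter) leaves the two within the scatter of each other. Compound 3 `COc1ccc2cccc(CCC(N)=O)c2c1` differs from compound 2 by a group of 4 heavy atoms (2 carbon, 1 nitrogen, 1 oxygen; no ring) in place of a group of 5 heavy atoms (2 carbon, 1 nitrogen, 2 oxygen; no ring), on a saturated chain carbon bound to an aromatic carbon. This alters the same chain that the change from compound 1 to compound 2 altered, and that change barely moved the number, so only a modest step in this assay is expected, if anything toward a slightly higher number. Compound 3 is estimated at 20 nM, with a likely range from 5 nM to 80 nM, an expected step of a 2.5-fold higher number from compound 2 to compound 3 (0.40 log units; beyond the scatter).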

Compound 3, half-maximal inhibitory concentration: 1000 nM
For compound 3 the middle estimate is 50-fold (1.70 log units) below the measured one; the whole stated range lies below it.
By their numbers in this assay, from the lowest: compounds 2 and 1 (each within the scatter of the next); then compound 3.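

In this assay, the chain on the saturated carbon bound to an aromatic carbon turns out to be sensitive to change, which compound 1 and compound 2 did not reveal. Replacing the group in compound 2 with carbamoylmethyl gives a 130-fold higher number from compound 2 to compound 3 (2.10 log units; beyond the scatter), while hydrogen in place of methyl on the amide-type nitrogen gives a 79-fold higher number from compound 1 to compound 3 (1.90 log units; beyond the scatter), so in this pair that methyl matters greatly. Nothing available accounts for this loss. Still open, on these data alone, is whether an ethyl group or a longer chain on that nitrogen would keep the low number, and how an amine would fare in place of the amide.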